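Methoxy-to-fluoro swap on two cores: cytotoxicity notes

The source may report more compounds than this note shows. Statements on the series, on what has been measured and on what is new or still open speak of the compounds shown alone.

Compound 1 `COc1ccc(/C=C/C(=O)c2cc(NC(C)=O)ccc2O)cc1` and compound 2 `CC(=O)Nc1ccc(O)c(C(=O)/C=C/c2ccc(F)cc2)c1` share one core; compound 3 `COc1cccc(-c2oc3ccc(N)cc3c(=O)c2O)c1` and compound 4 `Nc1ccc2oc(-c3cccc(F)c3)c(O)c(=O)c2c1` share another. The difference between the two cores is not broken down here.

In an ADME assay on MT4 cells (Homo sapiens) for cytotoxicity, read by MTT assay, with a stated time of 4 days (a higher number here means that more compound is tolerated, a lower number that less compound is tolerated), compound 1 gives 38700 nM. In this assay compound 2 gives 41100 nM. The step between them, a 1.1-fold higher number from compound 1 to compound 2 (0.03 log units; within the scatter), belongs to the change (fluoro in place of methoxy on an aromatic carbon). In this assay compound 3 gives 40800 nM; its values against compound 2 and compound 1 sit within the scatter, so no order among the three is read.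

Compound 4 arises from compound 3 by fluoro in place of methoxy on an aromatic carbon. This is the same kind of change as that from compound 1 to compound 2, but not the same: in the earlier pair the place is para to a large group, in the present pair it is meta to a large group, and the cores differ. Going by the values given here, the earlier step in this assay was within the scatter, and the three measured compounds lie close together, so an expected step of about the same size, a 1.1-fold higher number from compound 3 to compound 4 (0.02 log units; within the scatter), is the working assumption; nothing among the measured compounds supports a larger move. Compound 4 is therefore estimated at 43000 nM in this assay, with the range 24000 nM to 78000 nM reflecting the scatter of this kind of measurement and the change of core.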

Compound 4, half-maximal cytotoxic concentration: 35300 nM
For compound 4 the middle estimate is 1.2-fold (0.09 log units) above the measured one; the measured number falls inside the stated range.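

In this assay, fluoro in place of methoxy on an aromatic carbon gives a 1.2-fold lower number from compound 3 to compound 4 (0.06 log units; within the scatter), so on this core the swap produces no readable shift in the tolerated concentration. Set beside the earlier pair, the change behaves alike on both cores, and no difference between the two steps can be read: the same change on two cores in this assay, a 1.1-fold higher number (0.03 log units; within the scatter) from compound 1 to compound 2 and a 1.2-fold lower number (0.06 log units; within the scatter) from compound 3 to compound 4, 1.2-fold (0.09 log units) apart, within the scatter of two such steps

This supports only a narrow statement: in these two pairs, the swap leaves the cytotoxicity read-out inside the usual scatter, and carrying it from one core to the other introduces no detectable change. It does not show that the swap is without effect in general, and it cannot separate core from place, since the two pairs differ in both; with both steps inside the scatter, there is also no real effect here whose transfer could be tested.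

The compounds shown carry only methoxy or fluoro at the changed place, so it remains open whether an amine, a carboxylic acid or a longer chain such as ethoxy there would give a step beyond the scatter. Also open, on these data alone, is whether the swap would stay this quiet on a third core.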